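The compounds below may be only part of what the source reports. "The series", "measured", "known", "first", "only" and "open" are said of these compounds alone.

Compound 2, `COc1nc2ccc(Br)cc2cc1C(c1ccccc1)n1cc(-c2cccc(F)c2)nn1`, belongs to a pair of compounds sharing one core and differing only in the group on an aromatic carbon of the five-membered ring with three nitrogens. In an ADME assay on SK-OV-3 cells (Homo sapiens) for cytotoxicity, read by sulforhodamine B assay, with a stated time of 48 h, tested at 10 uM (on this read-out lower numbers stand for less inhibition and higher numbers for more inhibition at the one concentration tested (going by the name of the read-out)), compound 2 gives 12.7%, and its companion compound 1, `CCCCCCCc1cn(C(c2ccccc2)c2cc3cc(Br)ccc3nc2OC)nn1`, gives 10.5%. Within the data shown here, the one measured step, a number 2.2 percentage points higher from compound 1 to compound 2 (within the scatter), shows that exchanging heptyl for 3-fluorophenyl at this position left the read-out essentially unmoved, so compound 2 stands level with compound 1 within the scatter.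

Compound 3, `COc1nc2ccc(Br)cc2cc1C(c1ccccc1)n1cc(C2CC2)nn1`, takes the step (cyclopropyl in place of 3-fluorophenyl on an aromatic carbon). Among the measured compounds shown here, the only step that bears on it is the one from compound 1 to compound 2: a far larger swap at the same aromatic carbon than the present one produced no movement beyond the scatter. On that basis compound 3 is expected to behave much like compound 2, with an expected step of a number 2.7 percentage points lower from compound 2 to compound 3 (within the scatter) in the same assay, in no clear direction. The estimate for compound 3 in this assay is therefore 10%, with a range from 0% to 24%.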

Compound 3, a percentage reported as inhibition, at one concentration (the size of the read-out at that concentration, not a potency): 3.52%
Beside the measured number, compound 3's estimate is 6.5 percentage points above it; measured number inside the range.
By their numbers in this assay, from the lowest: compounds 3, 1 and 2 (each within the scatter of the next).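

With cyclopropyl, this aromatic carbon of the five-membered aromatic ring with 3 nitrogen has now carried a heptyl chain, a six-membered aromatic ring and a three-membered non-aromatic ring, and in this assay both a number 9.2 percentage points lower from compound 2 to compound 3 (within the scatter) and a number 7 percentage points lower from compound 1 to compound 3 (within the scatter) stay within the scatter. The earlier step compared two large groups, whereas these steps add a much smaller group, and the read-out still does not separate it from either larger one, so across these three compounds neither the size of the group nor the presence of an aromatic ring shows a clear effect at this one concentration. Nothing shown gives a reason for this lack of separation.

The compounds shown leave open whether a group of a different kind at this carbon, such as an amine or a carboxylic acid, would move the number beyond the scatter. They also leave open whether changing the shared core elsewhere, for instance exchanging the bromine or the methoxy group, would have any larger effect in this assay than the changes seen at this position.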